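The compounds below may be only part of what the source reports. "The series", "measured", "known", "first", "only" and "open" are said of these compounds alone.

Compound 3 `Cc1nc(N)c2c(-c3cccs3)cn([C@@H]3O[C@H](CO)[C@@H](O)[C@H]3O)c2n1` stands only at a limit on the numbers shown. In a functional assay on CCRF-CEM cells (Homo sapiens), read by MTT assay, with a stated time of 72 h (on this read-out lower numbers stand for stronger inhibition and higher numbers for weaker inhibition), compound 3 gives > 20000 nM, which is a limit of the assay and not a number. Compound 2 `Cc1nc(N)c2c(-c3ccsc3)cn([C@@H]3O[C@H](CO)[C@@H](O)[C@H]3O)c2n1` is in the same position: in this assay compound 2 gives > 20000 nM, again a limit. The step that the two limits leave unreadable from compound 2 to compound 3 is unreadable because of the limit of > 20000 nM in this assay, at which 2 of the 3 values shown sit. Compound 1 `COc1ncnc2c1c(I)cn2[C@@H]1O[C@H](CO)[C@@H](O)[C@H]1O` is the only one of the three with a number: in this assay compound 1 gives 1150 nM.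

Compound 4 `Cc1nc(N)c2c(I)cn([C@@H]3O[C@H](CO)[C@@H](O)[C@H]3O)c2n1` has not yet been measured. It differs from compound 3 in one place: iodo in place of thiophen-2-yl on an aromatic carbon. For the measured compounds named here, no measured step bears directly on this exchange; the single measured step, a step that the two limits leave unreadable from compound 2 to compound 3, swaps one thiophenyl for the other and its size cannot be read. Compound 1 also carries iodo on its core, though its other groups differ from those of compound 4, and in this assay compound 1 gives 1150 nM. On that basis compound 4 is expected to give 3000 nM, within a range from 500 nM to 20000 nM. The step of an at least 6.6-fold lower number from compound 3 to compound 4 (0.82 log units; beyond the scatter) that this estimate implies is expected to run toward stronger inhibition, though its size cannot be fixed against a limit.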

Compound 4, half-maximal inhibitory concentration: 9030 nM
The estimate for compound 4 lay 3.0-fold (0.48 log units) below the measured number, and the stated range covers the measured number.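

In this assay the aromatic carbon two ring bonds from the ring nitrogen now gives a readable change on the shared core, which the two thiophenyl compounds alone could not show. Exchanging the ring for iodo gives an at least 2.2-fold lower number from compound 3 to compound 4 (0.34 log units; beyond the scatter) and likewise an at least 2.2-fold lower number from compound 2 to compound 4 (0.34 log units; beyond the scatter) on the same core, so among these three compounds only the one carrying iodo returns a number, and it lies on the side of stronger inhibition. Both steps start from a limit of the assay and not from a number, so they give only a lower bound on the size of the change.

As far as these compounds go, whether bromo, ethynyl or a phenyl ring at this carbon would stand with iodo or with the two thiophenyl groups remains open, and so does how far the number would move with any of them. The step between the thiophen-3-yl and thiophen-2-yl compounds still cannot be read, because both stand at a limit: the limit of > 20000 nM in this assay, at which 2 of the 4 values shown sit.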